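Swapping Methoxy for Trifluoromethyl on the Best Compound

A few compounds are considered here, and "the series" means these few. Any claim that something is new, unique, unknown or untested is made for them only; others in the source may bear on it.

compound 1 `FC(F)(F)c1ccc(-c2nn(-c3ccccc3)cc2-c2nc3ccccc3[nH]2)cc1` gives 6030 nM
compound 2 `Cc1ccc(-c2nn(-c3ccccc3)cc2-c2nc3ccccc3n2S(=O)(=O)c2ccc(Br)cc2)cc1` gives 3040 nM
compound 3 `COc1ccc(S(=O)(=O)n2c(-c3cn(-c4ccccc4)nc3-c3ccc(F)cc3)nc3ccccc32)cc1` gives 470 nM

In a functional assay on HepG2 cells (Homo sapiens) for antiproliferative activity, read by MTT assay, with a stated time of 24 h (on this read-out lower numbers stand for stronger inhibition and higher numbers for weaker inhibition), compound 3 has the lowest number of the three (470 nM), clearly stronger than compound 2 (3040 nM) and compound 1 (6030 nM). These three differ from each other in more than one place, so they do not show what any single change does.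

The next compound, compound 4 `O=S(=O)(c1ccc(C(F)(F)F)cc1)n1c(-c2cn(-c3ccccc3)nc2-c2ccc(F)cc2)nc2ccccc21`, keeps all of compound 3 except one group: trifluoromethyl in place of methoxy on an aromatic carbon, para to a large group (trifluoromethyl in place of methoxy on an aromatic carbon). Going by the values given here, no measured pair tests this swap, so the expectation starts from compound 3 (470 nM) and carries a wide range. In this assay a small step is expected, probably not beyond the usual scatter of repeated measurements, and leaning toward weaker inhibition: an estimated 1.6-fold higher number from compound 3 to compound 4 (0.20 log units; within the scatter) overall. The expected value for compound 4 is 750 nM (expected range 200 nM to 2800 nM).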

Compound 4, half-maximal inhibitory concentration: 1680 nM
Estimate against measurement, compound 4: 2.2-fold (0.35 log units) below; the range from low to high includes it.
By their numbers in this assay, from the lowest: compound 3; then compounds 4, 2 and 1 (each within the scatter of the next, the first and the last beyond it).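

Going from 4-methoxyphenyl to 4-(trifluoromethyl)phenyl, with the rest of the molecule unchanged, gives a 3.6-fold higher number from compound 3 to compound 4 (0.55 log units; beyond the scatter) in this assay, so inhibition weakens. Going by these compounds alone, this is the first comparison here that isolates a single change, and it shows that the group at this place affects the result, with methoxy ahead of trifluoromethyl in this pair. Nothing available here bears on why the number rises.

With only these two groups compared at this place, a single swap cannot show how other groups would behave: an amine, a carboxylic acid or a longer chain such as ethoxy could fall on either side of compound 3. From the compounds shown here alone, it also remains open whether the same swap would have a similar effect with the other parts of the molecule changed.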